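This account rests on a few compounds, and the source may have more. Where it says the series, first, only, none or still open, it means among the compounds named here.

Compounds measured so far:

compound 1 `COc1ccc(/C(F)=C/c2cc(OC)c(OC)c(OC)c2)cc1F`: 610000 nM
compound 2 `COc1ccc(/C(F)=C/c2cc(OC)c(OC)c(OC)c2)cc1[N+](=O)[O-]`: > 3000000 nM

In a functional assay on cells (Endothelial cell, Bos taurus) for antiproliferative activity (on this read-out lower numbers stand for stronger inhibition and higher numbers for weaker inhibition), compound 1 gives 610000 nM, the only number shown in this series. Compound 2, with a nitro in place of fluoro on an aromatic carbon, reaches only a limit of the assay in this assay, > 3000000 nM; this is the limit described by the limit of > 3000000 nM in this assay, at which 1 of the 2 values shown sits. Within the data shown here, that change, an at least 4.9-fold higher number from compound 1 to compound 2 (0.69 log units; beyond the scatter), is the only measured step, and it does not involve the double bond.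

Compound 3 `COc1ccc(/C(F)=C\c2cc(OC)c(OC)c(OC)c2)cc1F` differs from compound 1 in one respect: the two compounds have the same atoms and bonds and differ only in configuration as drawn: 1 of 1 stereo elements differ; a double bond is drawn Z in compound 1 and E in compound 3. Among the measured compounds shown here, no measured step touches this kind of change, so the account rests on compound 1 alone, which already sits close to the limit of this assay. Compound 3 is expected to give a weaker result, a 4.1-fold higher number from compound 1 to compound 3 (0.61 log units; beyond the scatter), with a fair chance that only a limit is reported. The estimate for compound 3 in this assay is 2500000 nM, within a range from 500000 nM to 10000000 nM.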

Compound 3, half-maximal inhibitory concentration: 23000 nM
Compound 3: middle estimate off by 110-fold (2.04 log units), on the high side; the measured number lies below the stated range.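

In this assay, reversing the double bond from Z to E, with nothing else altered, gives a 27-fold lower number from compound 1 to compound 3 (1.42 log units; beyond the scatter). Among these compounds, the only earlier step concerned a group on an aromatic carbon, so this is the first sign that the configuration of the double bond matters on its own, and that it can matter in the direction of stronger inhibition. The step can be assigned to the double bond alone because no other feature separates the pair: the fact that compounds 1 and 3 differ only in the configuration as drawn.

The compounds shown leave open whether the E form keeps its stronger inhibition when the fluoro on the aromatic carbon gives way to another group, such as nitro, an amine or a hydroxyl. They also leave open whether the same reversal has a step of similar size in compounds with those groups.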